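Alkoxy chain length on the shared core

A few compounds are considered here, and "the series" means these few. Any claim that something is new, unique, unknown or untested is made for them only; others in the source may bear on it.

Measured compounds:
compound 1 `CCCCOc1ccc(-c2c(C)[nH]c(=O)n2C)cc1` — 5100 nM
compound 2 `Cc1ccc(-c2c(C)[nH]c(=O)n2C)cc1` — 85300 nM
compound 3 `CCCCCOc1ccc(-c2c(C)[nH]c(=O)n2C)cc1` — 4500 nM

In a functional assay on brain (Rattus norvegicus, strain Wistar) for inhibition (a higher number here means a weaker inhibitor, a lower number a stronger inhibitor), compound 1 gives 5100 nM, the second highest of the three numbers; compound 3 sits nearest, compound 2 furthest. Compound 4 `CCCCCCOc1ccc(-c2c(C)[nH]c(=O)n2C)cc1` is unmeasured. From compound 1 to compound 4 the change is ethyl in place of hydrogen on a saturated chain carbon, four bonds along the chain from an oxygen on an aromatic ring.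

Within the data shown here, two measured steps bear on this. The closest analogue is the one-carbon extension of the alkoxy chain: a 1.1-fold lower number from compound 1 to compound 3 (0.05 log units; within the scatter). The other two steps, a 17-fold higher number from compound 1 to compound 2 (1.22 log units; beyond the scatter) and a 19-fold lower number from compound 2 to compound 3 (1.28 log units; beyond the scatter), show that replacing the alkoxy chain by methyl moves the number a long way, but they do not concern chain length among the alkoxy compounds. Among the measured compounds shown here, since lengthening butoxy to pentyloxy gave a 1.1-fold lower number from compound 1 to compound 3 (0.05 log units; within the scatter), adding two further chain carbons is expected to stay within the scatter, perhaps with a slight drift toward a lower number; no measured compound speaks against this, though none carries a chain this long either.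

Compound 4 is therefore expected to give 4000 nM, with a range of 1500 nM to 11000 nM, which means an expected step of a 1.3-fold lower number from compound 1 to compound 4 (0.11 log units; within the scatter).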

Compound 4, half-maximal inhibitory concentration: 7300 nM
For compound 4 the middle estimate is 1.8-fold (0.26 log units) below the measured one, and the stated range covers the measured number.
By their numbers in this assay, from the lowest: compounds 3, 1 and 4 (each within the scatter of the next); then compound 2.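

In this assay the step to hexyloxy gives a 1.4-fold higher number from compound 1 to compound 4 (0.16 log units; within the scatter) and a 1.6-fold higher number from compound 3 to compound 4 (0.21 log units; within the scatter) so that compounds 1, 3 and 4 cannot be ordered, and adding ethyl on the saturated chain carbon four bonds along from the oxygen on the aromatic ring shows no trend with chain length across butoxy, pentyloxy and hexyloxy. The separation from the methyl compound also holds at the longest chain shown, with a 12-fold lower number from compound 2 to compound 4 (1.07 log units; beyond the scatter) as a large step, so all three alkoxy compounds now stand well apart from compound 2 while remaining within the scatter of one another. No supporting data bear on why the number stays level along these three chains.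

Where the large step from methyl to the alkoxy compounds arises remains open, since the compounds shown hold no methoxy, ethoxy or propoxy chain to fill the gap between compound 2 and compound 1. From the compounds shown here alone, it is equally open whether the level stretch continues to a longer chain such as octyloxy, or survives an amine or a carboxylic acid at the end of the chain.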